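This account rests on a few compounds, and the source may have more. Where it says the series, first, only, none or still open, it means among the compounds named here.

Measured so far:
compound 1 `Cc1cc(O)c(C(=O)/C=C/c2ccccc2Cl)c(-c2ccc(Cl)cc2)c1C(=O)/C=C/c1ccccc1Cl` — 30000 nM
compound 2 `Cc1cc(O)c(C(=O)/C=C/c2ccc(Cl)cc2)c(-c2ccc(Cl)cc2)c1C(=O)/C=C/c1ccc(Cl)cc1` — "not active" (no number reported)

In an ADME assay on HEK293 cells (Homo sapiens) for cytotoxicity, read by MTT assay, with a stated time of 24 h (a lower number here means a stronger inhibitor, a higher number a weaker inhibitor), compound 1 gives 30000 nM. In this assay compound 2 is reported as "not active" (no number reported), so no single number stands for it; it sits at the weak end of what was measured, without a value to rank it against compound 1.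

Compound 3 `Cc1cc(O)c(C(=O)/C=C/c2ccc(Cl)cc2)c(-c2ccccc2)c1C(=O)/C=C/c1ccc(Cl)cc1` carries the change (hydrogen in place of chloro on an aromatic carbon), hydrogen in place of chloro on an aromatic carbon, para to a large group. For the measured compounds named here, no measured pair shows this step in this assay, so the expectation for the size of the change is none beyond the scatter, in either direction. Compound 3 is therefore expected to fall near 60000 nM, within 20000 nM to 200000 nM, with a real chance that this assay again reports only inactivity rather than a number.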

Compound 3, half-maximal inhibitory concentration: 10000 nM
Beside the measured number, compound 3's estimate is 6.0-fold (0.78 log units) above it, and the stated range ends above it.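

Compound 2 carries no number in this assay, so the step to compound 3 cannot be read. The compounds shown leave open how large a change 4-chlorophenyl to phenyl brings. No supporting evidence bears on this result.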